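Moving the Methylpyrazole Attachment in an Imidazoline Series

A few compounds are considered here, and "the series" means these few. Any claim that something is new, unique, unknown or untested is made for them only; others in the source may bear on it.

Compound 2 `Cn1nccc1-c1ccccc1NCC1=NCCN1` gives 10 nM in an in vitro functional assay on cells (Fibroblast) for agonist activity at Alpha-1A adrenergic receptor (Homo sapiens) (a higher number here means that more compound is needed for the effect, a lower number that less compound is needed), the highest of the two numbers; its nearest neighbour, compound 1 `c1ccc(-c2nc[nH]n2)c(NCC2=NCCN2)c1`, gives 0.794 nM. The step from compound 1 to compound 2 was a 13-fold higher number from compound 1 to compound 2 (1.10 log units; beyond the scatter). Compound 3 `Cn1ccc(-c2ccccc2NCC2=NCCN2)n1` differs from compound 2 by 1-methyl-1H-pyrazol-3-yl in place of 1-methyl-1H-pyrazol-5-yl on an aromatic carbon. That single step is the only one that bears on the change, and it shows the aryl ring at this carbon matters; an isomer of the same ring is expected to move less. Compound 3 is therefore estimated at 2.5 nM (range 0.8 nM to 8 nM), a step of a 4.0-fold lower number from compound 2 to compound 3 (0.60 log units; beyond the scatter) that is expected to lower the number.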

Compound 3, half-maximal effective concentration: 3.16 nM
Compound 3: the middle estimate sits 1.3-fold (0.10 log units) below what was measured; measured number inside the range.
By their numbers in this assay, from the lowest: compound 1; then compound 3; then compound 2.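

In this assay, the point of attachment of the methylpyrazole matters by itself: with the same atoms joined differently, 1-methyl-1H-pyrazol-3-yl in place of 1-methyl-1H-pyrazol-5-yl gives a 3.2-fold lower number from compound 2 to compound 3 (0.50 log units; beyond the scatter) and so recovers part of what the earlier change lost. The better isomer still does not reach the 1H-1,2,4-triazol-3-yl, with a 4.0-fold higher number from compound 1 to compound 3 (0.60 log units; beyond the scatter) remaining, so compound 1 keeps the lowest number of the three. Open, from the compounds shown here alone, is how an unmethylated 1H-pyrazol-3-yl or a 1-ethyl-1H-pyrazol-3-yl would stand on this aromatic carbon. Nothing available accounts for either step.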